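The source may report more compounds than this note shows. Statements on the series, on what has been measured and on what is new or still open speak of the compounds shown alone.

Measured compounds in an assay (Equus caballus) for inhibition of Thromboxane-A synthase (Homo sapiens), using microsomes; on this read-out higher numbers stand for weaker inhibition and lower numbers for stronger inhibition:
- compound 1 `CCOC(=O)CCCC/C=C(\c1ccccc1)c1cccnc1`: 600 nM
- compound 2 `O=C(O)C(CCC/C=C(\c1ccccc1)c1cccnc1)Sc1ccccc1`: 33 nM
- compound 3 `CC(C)(CCCC/C=C(/c1ccccc1)c1cccnc1)C(=O)O`: 38 nM

Among these three, compound 2 has the lowest number. Compound 3 sits nearest to it, and that gap lies within the usual scatter, so no order can be read between compound 2 and compound 3. Compound 1 stands furthest from compound 2, with a gap well beyond the scatter, so compound 1 is the weaker inhibitor of the pair.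

The next compound, compound 4 `CSC(CCC/C=C(\c1ccccc1)c1cccnc1)C(=O)O`, has not yet been measured in this assay. Its difference from compound 2 is a single one: methyl in place of phenyl on a sulfur. Among the measured compounds shown here, no measured pair carries this same change, so the size of its effect is not known from the data. Given that compound 2 gives 33 nM and that the change removes a ring, a modest shift toward a higher number is expected, though it may still fall within the scatter. The expected step is a 2.4-fold higher number from compound 2 to compound 4 (0.38 log units; beyond the scatter), a small weakening. Compound 4 is estimated at 80 nM, with a range from 30 nM to 250 nM.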

Compound 4, half-maximal inhibitory concentration: 30 nM
Compound 4: the middle estimate sits 2.7-fold (0.43 log units) above what was measured; the measured number falls inside the stated range.
By their numbers in this assay, from the lowest: compounds 4, 2 and 3 (each within the scatter of the next); then compound 1.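

In this assay the step with methyl in place of phenyl on the sulfur is a 1.1-fold lower number from compound 2 to compound 4 (0.04 log units; within the scatter) and so leaves no readable order: at this position the six-membered aromatic ring is not required for a number in this range. The step of a 20-fold lower number from compound 1 to compound 4 (1.30 log units; beyond the scatter) is large, but it swaps carboxy(methylsulfanyl)methyl for (ethoxycarbonyl)methyl as one change, so the share of the acid and the share of the methylsulfanyl group cannot be separated. Nothing available explains why the sulfur substituent can be exchanged in this way.

From the compounds shown here alone, whether the sulfur itself is needed stays open, as an ether oxygen or a plain methylene at that place would show. Also open, going by these compounds, is how a larger group on the sulfur, such as benzyl or a cyclohexyl ring, would read.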